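The source may hold more compounds than are shown below. What is called first, only, known or untested is meant among the compounds shown, and "the series" means these compounds.

Measured in a functional assay on HepG2 cells (Homo sapiens) for inhibition, read by MTT assay, with a stated time of 48 h; a higher number here means a weaker inhibitor, a lower number a stronger inhibitor:
compound 1 `COc1ccc(-c2nc3ccccn3c2Sc2ccccc2)cc1`: 54200 nM
compound 2 `C(=C/c1nc2ccccn2c1Sc1ccccc1)\c1ccccc1`: 8800 nM

Of these two, compound 2 has the lower number, 8800 nM, and so stands as the stronger inhibitor of the pair. The next compound is compound 3 `N#Cc1ccc(-c2nc3ccccn3c2Sc2ccccc2)cc1`, which has 4-cyanophenyl in place of 2-phenylethenyl on an aromatic carbon.

Within the data shown here, only one measured step bears on this change. It is the modest step of a 6.2-fold lower number from compound 1 to compound 2 (0.79 log units; beyond the scatter), beyond the scatter, in which 2-phenylethenyl replaced 4-methoxyphenyl on the same aromatic carbon. Compound 3 gives up 2-phenylethenyl and again carries a substituted phenyl there, as does compound 1 with its 54200 nM. Part of that gain is therefore expected to be lost in this assay. Among the measured compounds shown here, no measured compound carries 4-cyanophenyl, so the data do not show how much of it goes, and the expectation remains loose. The estimated change is a 2.8-fold higher number from compound 2 to compound 3 (0.45 log units; beyond the scatter), a moderate step towards a higher number. For compound 3 the expected value is 25000 nM, with an estimated range from 8000 nM to 80000 nM.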

Compound 3, half-maximal inhibitory concentration: 15700 nM
Compound 3: the middle estimate sits 1.6-fold (0.20 log units) above what was measured; the range from low to high includes it.
By their numbers in this assay, from the lowest: compounds 2 and 3 (each within the scatter of the next); then compound 1.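

In this assay the exchange of 2-phenylethenyl for 4-cyanophenyl gives a 1.8-fold higher number from compound 2 to compound 3 (0.25 log units; within the scatter) and so leaves the two groups indistinguishable at this aromatic carbon, which means that the double bond outside aromatic rings in 2-phenylethenyl is not required for a number in this range. The earlier step alone could not separate the loss of 4-methoxyphenyl from the arrival of 2-phenylethenyl, but keeping the phenyl ring and changing only its substituent, cyano in place of methoxy, gives a 3.5-fold lower number from compound 1 to compound 3 (0.54 log units; beyond the scatter) and shows that a substituted phenyl can also carry a lower number than compound 1 does. No measurement given here explains either step.

The compounds shown leave open whether the difference between compound 1 and compound 3 comes from adding cyano or from removing methoxy, and the plain phenyl, a phenyl bearing an amine or a carboxylic acid, and cyano moved elsewhere on the ring would each bear on that question. They also leave open whether a longer chain at this carbon, or a different group in place of the phenylsulfanyl group, would change the number further.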